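Swapping a chloro for two methyls on the aniline ring

The compounds below may be only part of what the source reports. "The series", "measured", "known", "first", "only" and "open" are said of these compounds alone.

Of the compounds shown here, three that share one core have been tested in a functional assay on HeLa cells (Homo sapiens) for inhibition, read by sulforhodamine B assay; a lower number here means a stronger inhibitor, a higher number a weaker inhibitor. Compound 1 `Cc1ccc(NC2=CC(=O)c3nc4n(c3C2=O)[C@H]2OC[C@@H](O)[C@H]2OC4)cc1` gives 3860 nM. Compound 2 `COc1cccc(NC2=CC(=O)c3c(nc4n3[C@H]3OC[C@@H](O)[C@H]3OC4)C2=O)c1` gives only a limit, > 8000 nM, so its number is not known. Compound 3 `O=C1C(Nc2cccc(Cl)c2)=CC(=O)c2c1nc1n2[C@H]2OC[C@@H](O)[C@H]2OC1` gives 7970 nM, the higher of the two readable numbers; compound 1 sits lower by a gap beyond the usual scatter.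

Compound 4 `Cc1ccc(NC2=CC(=O)c3c(nc4n3[C@H]3OC[C@@H](O)[C@H]3OC4)C2=O)cc1C` differs from compound 3 in one place: 3,4-dimethylphenyl in place of 3-chlorophenyl on an amine nitrogen. Among the measured compounds shown here, only one measured step touches that same ring, a number no higher from compound 2 to compound 3 (the limit leaves the size open), and its size cannot be read because of the limit of > 8000 nM in this assay, at which 1 of the 3 values shown sits. Beyond that, the values of compound 1 and compound 3 show that a ring bearing a single methyl gave a lower number than a ring bearing a chloro, though no step between them is measured.

Compound 4 is therefore expected to land near 5000 nM, somewhere between 2000 nM and 9000 nM. The expected step, a 1.6-fold lower number from compound 3 to compound 4 (0.20 log units; within the scatter), is a modest move toward a lower number, close to the edge of the scatter.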

Compound 4, half-maximal inhibitory concentration: 4320 nM
Compound 4: middle estimate off by 1.2-fold (0.06 log units), on the high side; the measured number falls inside the stated range.
By their numbers in this assay, from the lowest: compounds 1, 4 and 3 (each within the scatter of the next, the first and the last beyond it). At a limit, above all of these: compound 2.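

In this assay, among the compounds shown here, the first step of readable size at this amine nitrogen is a 1.8-fold lower number from compound 3 to compound 4 (0.27 log units; within the scatter), so 3,4-dimethylphenyl and 3-chlorophenyl cannot be told apart here. The comparison with the 3-methoxyphenyl ring of compound 2 gives only a floor: an at least 1.8-fold lower number from compound 2 to compound 4 (0.26 log units; that floor lies within the scatter). The true size of that step stays open because the value for compound 2 is a limit of the assay: the limit of > 8000 nM in this assay, at which 1 of the 4 values shown sits.

On these data alone, it remains open whether an amine or a carboxylic acid on this ring, or a longer chain in place of the two methyls, would give a number clearly apart from these. As far as these compounds go, the result for a plain phenyl ring at this nitrogen, with no group on it, is also open.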